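The source may report more compounds than this note shows. Statements on the series, on what has been measured and on what is new or still open speak of the compounds shown alone.

Measured so far, in a functional assay on the whole organism for antagonist activity, with Mus musculus as the target; a lower number here means that less compound is needed, a higher number that more compound is needed for the effect:
Compound 1 `COc1cc(N)c(Cl)cc1NC(=O)C1CCN(CC2CCCC2)CC1`: compound 1 gives > 10 mg/kg, which is a limit of the assay rather than a number.
Compound 2 `COc1cc(N)c(Cl)cc1NC(=O)C1CCN(Cc2ccc(F)cc2)CC1`: compound 2 gives 0.6 mg/kg.

Compound 2 therefore holds the only real number shown; the other value is a limit. Compound 3 `COc1cc(N)c(Cl)cc1NC(=O)C1CCN(Cc2cccc(Cl)c2)CC1` differs from compound 2 by 3-chlorophenyl in place of 4-fluorophenyl on a saturated chain carbon bound to an amine nitrogen in a ring. Among the measured compounds shown here, the one measured step, an at least 16-fold lower number from compound 1 to compound 2 (1.22 log units; beyond the scatter), replaces cyclopentyl with 4-fluorophenyl and so does not speak to exchanging one halogen-bearing phenyl for another. For the measured compounds named here, with no step bearing on this change, compound 3 is expected to stay near compound 2, with an estimated step of a 1.3-fold higher number from compound 2 to compound 3 (0.12 log units; within the scatter) that remains within the scatter. Compound 3 is thus estimated at 0.8 mg/kg, ranging from 0.3 mg/kg to 3 mg/kg.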

Compound 3, dose for half-maximal effect: > 4 mg/kg
Compound 3: a limit, no number (the forecaster's own chance of this, stated with the estimate: 10%); at least 5.0-fold (0.69 log units) between middle value and limit.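

In this assay, replacing 4-fluorobenzyl with 3-chlorobenzyl on the shared core gives an at least 6.6-fold higher number from compound 2 to compound 3 (0.82 log units; beyond the scatter), showing that a halogen-bearing phenyl at this position does not by itself keep the low dose of compound 2. Compound 3 gives > 4 mg/kg, which is a limit of the assay and not a number. Compound 1 also stands at a limit, and the step between these two cannot be read.

Open, as far as these compounds go, is which part of the change counts, the halogen or its place on the ring, a question that 4-chlorophenyl or 3-fluorophenyl could settle.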